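This account rests on a few compounds, and the source may have more. Where it says the series, first, only, none or still open, it means among the compounds named here.

Measured so far in a functional assay on CAKI-1 cells (Homo sapiens) for inhibition, read by sulforhodamine B assay, with a stated time of 48 h; on this read-out higher numbers stand for weaker inhibition of growth and lower numbers for stronger inhibition of growth:
Compound 1 `COc1ccc(-c2[nH]c3ccccc3c2/C=C(\C#N)S(=O)(=O)c2ccccc2)cc1` gives 997 nM.
Compound 2 `COc1ccc(-c2[nH]c3ccc(OC)cc3c2/C=C(\C#N)S(=O)(=O)c2ccccc2)cc1` gives 4200 nM.
Compound 3 `CC(=O)/C(=C\c1c(-c2ccccc2)[nH]c2ccccc12)S(=O)(=O)c1ccccc1` gives 2400 nM.

Compound 2 shows the highest number of the three, with compound 3 within the scatter and compound 1 beyond it. Compound 4 `COc1ccc2[nH]c(-c3ccccc3)c(/C=C(\C#N)S(=O)(=O)c3ccccc3)c2c1` differs from compound 2 in one place: hydrogen in place of methoxy on an aromatic carbon, so the 4-methoxyphenyl becomes plain phenyl. For the measured compounds named here, only one measured step involves a methoxy, at a different place and in the other direction: a 4.2-fold higher number from compound 1 to compound 2 (0.62 log units; beyond the scatter). That step cannot be carried over directly, and compound 3, which also carries plain phenyl, stands within the scatter of compound 2. A small shift toward a lower number is therefore expected for compound 4, a 1.7-fold lower number from compound 2 to compound 4 (0.23 log units; within the scatter), with no confidence that it exceeds the scatter. Compound 4 is estimated at 2500 nM, in the range 900 nM to 7000 nM.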

Compound 4, concentration for 50% growth inhibition: 4500 nM
Beside the measured number, compound 4's estimate is 1.8-fold (0.26 log units) below it; the range from low to high includes it.
By their numbers in this assay, from the lowest: compound 1; then compounds 3, 2 and 4 (each within the scatter of the next).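

Going from 4-methoxyphenyl to phenyl in this assay gives a 1.1-fold higher number from compound 2 to compound 4 (0.03 log units; within the scatter), so this methoxy can be replaced by hydrogen with no readable change in growth inhibition while the core methoxy of compound 2 stays in place. For the compounds shown here, the only other methoxy step, at a different place, gave a 4.2-fold higher number from compound 1 to compound 2 (0.62 log units; beyond the scatter), so the two places do not behave alike here. No measurement on hand offers an explanation for this difference. Still open, from the compounds shown here alone, is whether an amine or a carboxylic acid at this place would shift the number beyond the scatter. Also open, going by these compounds, is whether the same swap would read alike on the core of compound 1.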